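Swapping methoxy for chloro on an inactive pyridine amide series

The compounds below may be only part of what the source reports. "The series", "measured", "known", "first", "only" and "open" are said of these compounds alone.

Measured so far:
- Compound 1 `COc1cccnc1C(=O)Nc1nn[nH]n1`: 0%
- Compound 2 `O=C(Nc1nn[nH]n1)c1cccnc1`: 3%
- Compound 3 `O=C(Nc1nn[nH]n1)c1cccc(Oc2ccccc2)n1`: 0%

Three compounds share one core, an amide linking a tetrazole to a pyridine, and all three have been tested in a functional assay on the whole organism for inhibition, with Rattus norvegicus as the target, at a dose of 10 mg/kg by the oral route; a lower number here means a weaker effect, a higher number a stronger effect of the compound at the dose given. In this assay compound 1 gives 0%, the same number as compound 3, and the number for compound 2 lies within the usual scatter of both. None of the three shows a measurable effect at this dose, so compound 1 stands level with the others.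

Compound 4 `O=C(Nc1nn[nH]n1)c1ncccc1Cl` has not yet been tested. It differs from compound 1 in one place: chloro in place of methoxy on an aromatic carbon.

Within the data shown here, with no step between measured compounds to lean on, and three flat results, no change beyond the scatter is expected from compound 1 to compound 4 in this assay; the estimated step is a number 2 percentage points higher from compound 1 to compound 4 (within the scatter). Compound 4 is therefore expected to give about 2%, within a range from 0% to 15%.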

Compound 4, a percentage reported as inhibition, in the whole organism at one dose (the size of the read-out at that dose, not a potency): 22%
For compound 4 the middle estimate is 20 percentage points below the measured one; measured number outside the range, above it.
By their numbers in this assay, from the lowest: compounds 1, 3 and 2 (each within the scatter of the next); then compound 4.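

In this assay chloro in place of methoxy gives a number 22 percentage points higher from compound 1 to compound 4 (beyond the scatter) and so shows that this position on the shared core can change the read-out. Among the compounds shown, this is the only change in one place with a step that can be read, and it rests on this single pair. No measurement here explains the gain.

Still open, on these data alone, is whether chlorine itself matters, or whether another group at this position, such as fluoro, methyl or an amine, would do the same or more.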